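The source may report more compounds than this note shows. Statements on the series, on what has been measured and on what is new or still open speak of the compounds shown alone.

Compound 1 `COc1ccc(N2C(=O)COc3ccc(-c4cnc5ccccc5c4)cc32)cc1` is the reference point of the series. In a functional assay on HepG2 cells (Homo sapiens) for antiproliferative activity, read by MTT assay, with a stated time of 72 h (a higher number here means a weaker inhibitor, a lower number a stronger inhibitor), compound 1 gives only a limit, > 40000 nM. That limit is the limit of > 40000 nM in this assay, at which 1 of the 2 values shown sits. Compound 2 `COc1ncc(-c2ccc3c(c2)N(c2ccc(F)cc2)C(=O)CO3)cc1NS(=O)(=O)c1ccc(F)cc1` is the other measured member, and in this assay compound 2 gives 36400 nM. Among the compounds with values here, no two measured compounds differ in a single place, so no measured step is available. Compound 3 `O=C1COc2ccc(-c3cnc4ccccc4c3)cc2N1C1CCCCC1` carries cyclohexyl in place of 4-methoxyphenyl on an amide-type nitrogen in a ring. Both measured values sit at the weak end of this assay, and no step beyond the scatter is expected in either direction. Compound 3 is expected to give 40000 nM, within 15000 nM to 100000 nM, an estimated step of a number no higher from compound 1 to compound 3 (the limit leaves the size open).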

Compound 3, half-maximal inhibitory concentration: > 40000 nM
Compound 3: no number, only a limit; the forecaster's own chance of this, stated with the estimate: 60%; the middle value sits exactly at the limit.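

In this assay compound 3 and compound 1 each give only a limit, so no step between them can be read: the limit of > 40000 nM in this assay, at which 2 of the 3 values shown sit.

The compounds shown leave open whether cyclohexyl in place of 4-methoxyphenyl changes the read-out in this assay at all.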